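Swapping a Hydroxyphenyl for a Fluorophenyl on a Shared Core

The source may report more compounds than this note shows. Statements on the series, on what has been measured and on what is new or still open speak of the compounds shown alone.

Of the compounds shown here, three have been measured in a functional assay on DU-145 cells (Homo sapiens) for antiproliferative activity, read by MTT assay; on this read-out higher numbers stand for weaker inhibition and lower numbers for stronger inhibition. Compound 1 `Oc1cccc(Nc2nc(NCc3ccccc3)c3ccccc3n2)c1` gives 22600 nM. Compound 2 `O[C@H]1CCN(c2nc(Nc3cccc4c3CCCC4)c3ccccc3n2)C1` gives 16800 nM, a number that lies within the usual scatter of the number for compound 1, so the two cannot be told apart on this read-out. Compound 3 `O=[N+]([O-])c1cccnc1Sc1ccccc1NS(=O)(=O)c1ccc(Cl)cc1Cl` gives 53900 nM, a higher number than that of compound 1 by more than the scatter, meaning weaker inhibition. Compound 1 therefore has the second highest of the three numbers.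

Compound 4 `Fc1ccc(Nc2nc(NCc3ccccc3)c3ccccc3n2)cc1` has not yet been measured. It differs from compound 1 in one place: 4-fluorophenyl in place of 3-hydroxyphenyl on a nitrogen on an aromatic ring. The group that leaves carries one hydrogen-bond donor and one acceptor; the group that enters carries neither. Within the data shown here, no pair of measured compounds shows what such an exchange does on this assay, so there is no measured step to lean on.

With nothing to suggest a shift in either direction, compound 4 is expected to give about 21000 nM, within a range from 7000 nM to 63000 nM, which corresponds to an expected step of a 1.1-fold lower number from compound 1 to compound 4 (0.03 log units; within the scatter), that is, none beyond the scatter.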

Compound 4, half-maximal inhibitory concentration: 23400 nM
Compound 4: middle estimate off by 1.1-fold (0.05 log units), on the low side; low and high end bracket the measured number.
By their numbers in this assay, from the lowest: compounds 2, 1 and 4 (each within the scatter of the next); then compound 3.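

In this assay, replacing 3-hydroxyphenyl with 4-fluorophenyl on the nitrogen gives a 1.0-fold higher number from compound 1 to compound 4 (0.02 log units; within the scatter), so the two compounds cannot be told apart. Among these compounds, this is the first measured exchange at this position on the shared core. It shows that, in this one pair, the read-out stays within the scatter even though the hydrogen-bond donor and acceptor counted on 3-hydroxyphenyl are absent from 4-fluorophenyl, while no measurement available here bears on why the two compounds match.

Because the substituent and its printed ring position both differ in this exchange, the pair cannot show what either difference does alone. 3-Fluorophenyl or 4-hydroxyphenyl would separate the two, and a larger group such as 4-aminophenyl or 4-carboxyphenyl would test whether this position tolerates other exchanges.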